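The source may hold more compounds than are shown below. What is called first, only, known or untested is meant among the compounds shown, and "the series" means these compounds.

In a physicochemical assay for lipophilicity, using the shake flask method, in phosphate buffer, measured as octanol-water partition, with a stated time of 30 min, at pH 7.4 (on this read-out higher numbers stand for higher lipophilicity and lower numbers for lower lipophilicity), compound 3 (`CN(c1ccn(C)n1)c1cnc(NCc2c(F)ccc3c2CCO3)n2cnnc12`) gives 1.8 and stands level with compound 1 (`C[C@@H]1CC(=O)N(c2cnc(NCc3c(F)ccc4c3CCO4)n3cnnc23)C1`), which gives 1.8 as well. Together they hold the lowest of the three numbers. Compound 2 (`CN(c1ccccc1)c1cnc(NCc2c(F)ccc3c2CCO3)n2cnnc12`) gives 3.6 and is the highest.

The next structure is compound 4 (`O=C1CCCN1c1cnc(NCc2c(F)ccc3c2CCO3)n2cnnc12`), with 2-oxopyrrolidin-1-yl in place of methyl(1-methyl-1H-pyrazol-3-yl)amino on an aromatic carbon.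

For the measured compounds named here, compound 1 carries 4-methyl-2-oxopyrrolidin-1-yl at that same place, so its exchange with compound 3 is the closest precedent: the measured result is no change at the digits printed from compound 1 to compound 3 (within the scatter) for that exchange. The large steps both involve the methyl(phenyl)amino group of compound 2 (a number 1.80 log units higher from compound 1 to compound 2 (beyond the scatter) and a number 1.80 log units lower from compound 2 to compound 3 (beyond the scatter)), which compound 4 does not carry, so they bear on it little. Going by the values given here, no measured step isolates the methyl that compound 4 lacks relative to compound 1, which leaves the direction tentative.

In this assay the expected result is a number 0.30 log units lower from compound 3 to compound 4 (within the scatter) and thus a small downward step, not expected to lie beyond the scatter. The estimate for compound 4 is 1.5 (expected range 1.1 to 1.9).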

Compound 4, distribution coefficient: 1.3
Beside the measured number, compound 4's estimate is 0.20 log units above it; measured number inside the range.
By their numbers in this assay, from the lowest: compound 4; then compounds 1 and 3 (each within the scatter of the next); then compound 2.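

In this assay, for the compounds shown here, the methyl on the saturated ring carbon now has a measured step of its own, a number 0.50 log units lower from compound 1 to compound 4 (beyond the scatter), with hydrogen in place of methyl as the only change. The level standing of compound 1 and compound 3 therefore does not extend to the unsubstituted 2-oxopyrrolidin-1-yl group, which gives a number 0.50 log units lower from compound 3 to compound 4 (beyond the scatter) when it replaces methyl(1-methyl-1H-pyrazol-3-yl)amino on the aromatic carbon. Replacing methyl(phenyl)amino with the same group gives a number 2.30 log units lower from compound 2 to compound 4 (beyond the scatter), the widest step at this position among the compounds shown, with compound 2 and compound 4 now marking the two ends of the range. Nothing in hand accounts for these steps.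

Going by these compounds alone, the single methyl pair cannot show whether an ethyl, a hydroxyl or a second methyl on the same saturated ring carbon would move the number in this assay in the same direction or by a similar amount. From the compounds shown here alone, it also remains open how a six-membered lactam such as 2-oxopiperidin-1-yl, or a primary amine on the aromatic carbon, would stand against compound 4.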